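A few compounds are considered here, and "the series" means these few. Any claim that something is new, unique, unknown or untested is made for them only; others in the source may bear on it.

Going by the values given here, compound 2 `CCCC(=O)N1CCC(NS(=O)(=O)c2ccc(NC(=O)c3ccccn3)c3ccccc23)CC1` stands at the higher of the two numbers so far in an in vitro functional assay on CHO/Galpha16 cells for antagonist activity at C-C chemokine receptor type 8 (Homo sapiens), read by FLIPR (a higher number here means a weaker inhibitor, a lower number a stronger inhibitor), where compound 2 gives 41.7 nM; compound 1 `CCCC(=O)N1CCC(NS(=O)(=O)c2ccc(NC(=O)C3CCCCC3)c3ccccc23)CC1` gives 6.1 nM in this assay. Among the compounds with values here, the only measured step, a 6.8-fold higher number from compound 1 to compound 2 (0.83 log units; beyond the scatter), concerns a different change, cyclohexyl exchanged for pyridin-2-yl on the carbonyl carbon, and it bears on the present step only indirectly. Compound 3 `CCCC(=O)N1CCC(NS(=O)(=O)c2ccc(NC(=O)c3cccnc3)c3ccccc23)CC1` differs from compound 2 by pyridin-3-yl in place of pyridin-2-yl on a carbonyl carbon. Within the data shown here, no measured pair moves the ring nitrogen from one position of the pyridyl to another, so the size of this step has no direct precedent; the step of a 6.8-fold higher number from compound 1 to compound 2 (0.83 log units; beyond the scatter) shows only that the aromatic ring itself is tolerated at this carbonyl carbon with a modest loss. The step of a 1.0-fold lower number from compound 2 to compound 3 (0.02 log units; within the scatter) is therefore expected to stay within the scatter. For compound 3 in this assay the estimate is 40 nM, with a range from 12 nM to 150 nM.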

Compound 3, half-maximal inhibitory concentration: 885 nM
For compound 3 the middle estimate is 22-fold (1.34 log units) below the measured one, outside the stated range (above it).
By their numbers in this assay, from the lowest: compound 1; then compound 2; then compound 3.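

In this assay the ring itself no longer accounts for the number at this carbonyl carbon: the two compounds have the same atoms joined differently, yet pyridin-3-yl in place of pyridin-2-yl gives a 21-fold higher number from compound 2 to compound 3 (1.33 log units; beyond the scatter) and lies well beyond the scatter. The earlier tolerance of an aromatic ring therefore applies to pyridin-2-yl and does not carry over to pyridin-3-yl, and measured against the cyclohexyl amide the change amounts to a 150-fold higher number from compound 1 to compound 3 (2.16 log units; beyond the scatter) in a large step. Nothing available explains why the two pyridyl isomers part so widely.

Open, from the compounds shown here alone, is where phenyl, with no ring nitrogen, and pyridin-4-yl would fall on the same carbonyl carbon. Also open, going by these compounds, is whether a methyl or an amino group on the pyridin-3-yl ring would change its number.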